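The compounds below may be only part of what the source reports. "The series", "measured", "known", "first", "only" and "open" are said of these compounds alone.

Working notes on the series in an assay on isolated protein for inhibition of steroid 17-alpha-hydroxylase/17,20 lyase (Homo sapiens); on this read-out higher numbers stand for weaker inhibition and lower numbers for stronger inhibition. Going by the values given here, compound 1 `CC(=O)Nc1cccc(-c2ccc(C(O)(c3c[nH]cn3)C(C)C)cc2)c1` gives 24 nM, the lowest number among the three measured so far. Compound 2 `CC(=O)Nc1cccc(-c2ccc([C@](O)(c3c[nH]cn3)C(C)C)cc2)c1`, the same structure with the carbinol centre drawn as S, gives 26 nM; the step of a 1.1-fold higher number from compound 1 to compound 2 (0.03 log units; within the scatter) is within the scatter, and the only point of difference is the fact that one of compounds 1 and 2 is drawn with a defined configuration and the other without, at the place where they differ. Compound 3 `CNS(=O)(=O)c1cccc(-c2ccc(C(O)(c3c[nH]cn3)C(C)C)cc2)c1` gives 160 nM; the step of a 6.7-fold higher number from compound 1 to compound 3 (0.82 log units; beyond the scatter) is modest but beyond the scatter.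

Compound 4 `CC(=O)Nc1cccc(-c2ccc(C(O)c3c[nH]cn3)cc2)c1` is not yet measured. It differs from compound 1 by hydrogen in place of isopropyl on a saturated chain carbon bound to two aromatic carbons and an oxygen on a saturated carbon. Neither measured step touches this place: the step from compound 1 to compound 2 concerns only the drawn configuration, and the step from compound 1 to compound 3 concerns the group on the aromatic carbon. No direct guide to the size of this step therefore exists, and the expectation rests only on the removal of the isopropyl branch from the carbinol carbon of the shared core. Compound 4 is expected to give 150 nM, within a range from 40 nM to 600 nM. The expected step of a 6.3-fold higher number from compound 1 to compound 4 (0.80 log units; beyond the scatter) is thus a modest rise, beyond the scatter but uncertain in size.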

Compound 4, half-maximal inhibitory concentration: 77 nM
The estimate for compound 4 lay 1.9-fold (0.29 log units) above the measured number; the range from low to high includes it.
By their numbers in this assay, from the lowest: compounds 1 and 2 (each within the scatter of the next); then compound 4; then compound 3.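

In this assay, the saturated chain carbon bound to two aromatic carbons and an oxygen on a saturated carbon proves sensitive to its substituent: hydrogen in place of isopropyl gives a 3.2-fold higher number from compound 1 to compound 4 (0.51 log units; beyond the scatter). The isopropyl group therefore contributes to the lower number of compound 1, but it is not required for inhibition, since compound 4 still gives 77 nM. Nothing available explains this step.

As far as these compounds go, whether a methyl or ethyl group at this carbon would give a number nearer to that of compound 1 or of compound 4 remains open. Also open, from the compounds shown here alone, is whether the same replacement would have a similar effect in the methylsulfamoyl compound 3.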